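Cytotoxicity notes: from compound 2 to compound 3

The source may report more compounds than this note shows. Statements on the series, on what has been measured and on what is new or still open speak of the compounds shown alone.

Compound 1 `Cc1cccc(Nc2nc(C)c(C(=O)/C=C/c3ccccc3Cl)s2)c1`: > 25000 nM
Compound 2 `Cc1nc(Nc2ccc(Cl)c(Cl)c2)sc1C(=O)/C=C/c1ccccc1`: 22700 nM

In a functional assay on NCI-H460 cells (Homo sapiens) for cytotoxicity, read by MTT assay (a higher number here means a weaker inhibitor, a lower number a stronger inhibitor), compound 1 reaches only a limit, > 25000 nM; this is a limit of the assay, not a number (the limit of > 25000 nM in this assay, at which 1 of the 2 values shown sits). For the measured compounds named here, compound 2 gives 22700 nM in this assay, the only number in the set. Compound 3 `Cc1ccc(Nc2nc(C)c(C(=O)/C=C/c3ccccc3)s2)cc1` differs from compound 2 by 4-methylphenyl in place of 3,4-dichlorophenyl on a nitrogen on an aromatic ring. Going by the values given here, no measured pair isolates this change, so no step can be read off. The expected step of a 1.2-fold higher number from compound 2 to compound 3 (0.09 log units; within the scatter) is none beyond the scatter, if anything toward weaker inhibition. Compound 3 is estimated at 28000 nM, between 12000 nM and 60000 nM, with a fair chance that only a limit is returned.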

Compound 3, half-maximal inhibitory concentration: > 25000 nM
Compound 3 ended at the assay's limit; the forecaster's own chance of this, stated with the estimate: 55%; the middle value is on the limit's open side.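

For the compounds shown here, at this position, 4-methylphenyl in place of 3,4-dichlorophenyl on a nitrogen on an aromatic ring gives an at least 1.1-fold higher number from compound 2 to compound 3 (0.04 log units; that floor lies within the scatter), the first step that can be read in this assay. Being only a floor, it fixes no size for this change. Compound 3 stands at a limit of the assay, not at a number, and limits now make up most of the series: the limit of > 25000 nM in this assay, at which 2 of the 3 values shown sit.

As far as these compounds go, how far past its limit compound 3 lies stays open. So does the reading for an amine or a carboxylic acid in place of 4-methylphenyl on that nitrogen.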